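Swapping an Aromatic Ring for a Saturated One

The compounds below may be only part of what the source reports. "The series", "measured", "known", "first", "only" and "open" are said of these compounds alone.

Compound 1 `COc1cc(-c2cnn3cc(OC)c(-c4cc(C)no4)nc23)ccn1`: 3000 nM
Compound 2 `COc1cn2ncc(-c3ccnc(OC(C)(C)C)c3)c2nc1-c1cnn(C)c1`: 800 nM

In an assay on isolated protein for inhibition of activin receptor type-2A (Homo sapiens), read by 33P incorporation, with a stated time of 20 min, in the presence of a further agent that is not named here (a higher number here means a weaker inhibitor, a lower number a stronger inhibitor), compound 1 gives 3000 nM, the highest of the two numbers; compound 2 gives 800 nM, a lower number beyond the usual scatter. Compound 3 `COc1cc(-c2cnn3cc(OC)c([C@H]4COC(C)(C)C4)nc23)ccn1` has not yet been measured. It differs from compound 1 in one place: a group of 7 heavy atoms (6 carbon, 1 oxygen; one five-membered non-aromatic ring with 1 hetero atom) in place of a group of 6 heavy atoms (4 carbon, 1 nitrogen, 1 oxygen; one five-membered aromatic ring with 2 hetero atoms), on an aromatic carbon. Going by the values given here, no measured pair shows this same change, so its effect is unknown; a small step is expected, with direction uncertain, as given by a 1.2-fold lower number from compound 1 to compound 3 (0.08 log units; within the scatter). For compound 3 the estimated value is 2500 nM, expected to fall between 600 nM and 10000 nM.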

Compound 3, half-maximal inhibitory concentration: 4100 nM
Estimate against measurement, compound 3: 1.6-fold (0.21 log units) below; the range from low to high includes it.
By their numbers in this assay, from the lowest: compound 2; then compounds 1 and 3 (each within the scatter of the next).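

In this assay, replacing the aromatic 3-methyl-1,2-oxazol-5-yl group with a saturated ring gives a 1.4-fold higher number from compound 1 to compound 3 (0.14 log units; within the scatter). This position of the shared core therefore tolerates a non-aromatic five-membered ring, with no change that can be told from the scatter. No measurement here explains this result. Still open, from the compounds shown here alone, is whether the opposite stereoisomer of the saturated ring would read the same, and whether an amine or a carboxylic acid on this aromatic carbon would shift the number beyond the scatter.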